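This account rests on a few compounds, and the source may have more. Where it says the series, first, only, none or still open, it means among the compounds named here.

Measured in a toxicity assay on HepG2 cells (Homo sapiens) for inhibition, read by CellTiter-Glo, with a stated time of 48 h; on this read-out higher numbers stand for weaker inhibition and lower numbers for stronger inhibition:
compound 1 `COc1ccc2c(OCC(=O)Nc3cc(C)cc(C)c3)cc(C)nc2c1`, 50100 nM
compound 2 `COc1ccc2nc(C)c(NC(=O)C(=O)Nc3cc(C)cc(C)c3)c(O)c2c1`, a limit, > 100000 nM
compound 3 `COc1ccc2nc(C)cc(OCC(=O)Nc3ccccc3)c2c1`, 39800 nM

Compound 3 stands at the lower of the two numbers in this assay, but compound 1 lies within the scatter of it, so the two cannot be told apart. Compound 2 sits at the limit of > 100000 nM in this assay, at which 1 of the 3 values shown sits.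

Compound 4 `COc1ccc2nc(C)cc(OCC(=O)Nc3c(C)cccc3C)c2c1` differs from compound 3 by 2,6-dimethylphenyl in place of phenyl on an amide-type nitrogen. Going by the values given here, no measured pair covers this change. The step of a 1.3-fold higher number from compound 3 to compound 4 (0.10 log units; within the scatter) is expected to be small, if anything toward a higher number, and not beyond the scatter. Compound 4 is thus expected to give about 50000 nM in this assay, with a range from 20000 nM to 100000 nM.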

Compound 4, half-maximal inhibitory concentration: > 100000 nM
Compound 4 ended at the assay's limit (the forecaster's own chance of this, stated with the estimate: 25%); at least 2.0-fold (0.30 log units) between middle value and limit.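

In this assay, going by these compounds alone, 2,6-dimethylphenyl in place of phenyl on an amide-type nitrogen gives an at least 2.5-fold higher number from compound 3 to compound 4 (0.40 log units; beyond the scatter), which is the first single-change step available. This position therefore does affect the read-out, and the change moves it toward weaker inhibition. The value of compound 4 is a limit and not a number: the limit of > 100000 nM in this assay, at which 2 of the 4 values shown sit.

From the compounds shown here alone, it remains open whether one methyl group on the phenyl would give a similar step. Going by these compounds, the effect of an amine or a carboxylic acid on the phenyl also remains open.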